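Compound 1 to compound 3: a methylcarbamoyl swap

The source may hold more compounds than are shown below. What is called first, only, known or untested is meant among the compounds shown, and "the series" means these compounds.

In a functional assay on HeLa cells (Homo sapiens) for inhibition, read by MTT assay, with a stated time of 72 h (a lower number here means a stronger inhibitor, a higher number a weaker inhibitor), compound 1 (`Nc1nc2cc(-c3nn(CCCCCCCCCC(=O)NO)c4ncnc(N)c34)ccc2o1`) reads > 50000 nM as its entry, which is a limit of the assay and not a number. Compound 2 (`Nc1ncnc2c1c(-c1cnc3[nH]ccc3c1)nn2CCCCCCCCCC(=O)NO`) gives 7560 nM in this assay and keeps the chain of compound 1 unchanged.

Compound 3 (`CNC(=O)CCCCCCCn1nc(-c2ccc3oc(N)nc3c2)c2c(N)ncnc21`) carries methylcarbamoyl in place of 2-(hydroxycarbamoyl)ethyl on a saturated chain carbon, seven bonds along the chain from an aromatic nitrogen, a difference counted as methylcarbamoyl in place of 2-(hydroxycarbamoyl)ethyl on a saturated chain carbon, seven bonds along the chain from an aromatic nitrogen and left on the shared core.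

Among the compounds with values here, the one measured step of an at least 6.6-fold lower number from compound 1 to compound 2 (0.82 log units; beyond the scatter) comes with a change of the aromatic group on the core. It leaves the chain as it is and so gives no size for the present change. Within the data shown here, no compound lacking 2-(hydroxycarbamoyl)ethyl has a measured value yet.

Compound 1 therefore remains the sole anchor, with its limit of > 50000 nM as the reason that no step beyond the scatter is expected in either direction. The estimated a number no higher from compound 1 to compound 3 (the limit leaves the size open) is read in that sense. Compound 3 is estimated at 50000 nM with an expected range from 15000 nM to 100000 nM and may well return only a limit.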

Compound 3, half-maximal inhibitory concentration: 12900 nM
Compound 3: middle estimate off by 3.9-fold (0.59 log units), on the high side; the whole stated range lies above it.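

Methylcarbamoyl in place of 2-(hydroxycarbamoyl)ethyl, on a saturated chain carbon seven bonds along the chain from an aromatic nitrogen, gives an at least 3.8-fold lower number from compound 1 to compound 3 (0.58 log units; beyond the scatter) in this assay, and this is the only measured step on the chain rather than on the aromatic group of the core. On the shared core, then, a hydroxycarbamoyl end is not needed for a measured value in this assay, and the chain position can shift the read-out beyond the scatter. The entry for compound 1 is a limit and not a number, and the size of the step stays open because of it: the limit of > 50000 nM in this assay, at which 1 of the 3 values shown sits.

The swap changes both the end group and the length of the chain, so the compounds shown cannot separate the two, and a chain of the length of compound 3 ending in hydroxycarbamoyl, or one ending in a carboxylic acid or a primary amide, would bear on that question. As far as these compounds go, whether the same swap gives a step of the same direction on the core of compound 2, which keeps the hydroxycarbamoyl chain, also remains open.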